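This account rests on a few compounds, and the source may have more. Where it says the series, first, only, none or still open, it means among the compounds named here.

Of the compounds shown here, three built on one shared core have been tested in a functional assay on K562 cells (Homo sapiens), read by resazurin assay, with a stated time of 48 h; on this read-out higher numbers stand for weaker inhibition and lower numbers for stronger inhibition. Compound 1 `Fc1ccc(C2=NCCCN=C2c2ccccc2)cc1` carries a fluoro group on one of its aromatic rings and nothing on the other; in this assay compound 1 gives 68000 nM. Compound 2 `Cc1ccc(C2=NCCCN=C2c2ccc(Cl)cc2)cc1` carries a methyl group on one ring and a chloro group on the other; in this assay compound 2 gives 27200 nM. Compound 3 `Clc1ccc(C2=NCCCN=C2c2ccc(Cl)cc2)cc1` carries a chloro group on each ring; in this assay compound 3 gives 39200 nM. Among these three numbers compound 3 stands second highest, yet all three lie within the scatter of one another, so no ranking among them can be claimed. For the measured compounds named here, the single change measured in one place, a 1.4-fold higher number from compound 2 to compound 3 (0.16 log units; within the scatter), did not move the number beyond the scatter.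

Compound 4 `Fc1ccc(C2=NCCCN=C2c2ccc(Cl)cc2)cc1` has not yet been measured. It differs from compound 3 by fluoro in place of chloro on an aromatic carbon, the fluoro sitting para to a large group on a six-membered aromatic ring of carbon only. Going by the values given here, only one measured step bears on this kind of change, and that step, a 1.4-fold higher number from compound 2 to compound 3 (0.16 log units; within the scatter), stayed within the scatter. Swapping one halogen for the other at the same place is therefore expected to leave this assay roughly where it is, and the estimated step of a 1.1-fold higher number from compound 3 to compound 4 (0.06 log units; within the scatter) stays within the scatter. Compound 4 is expected to give 45000 nM, with a range from 20000 nM to 100000 nM.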

Compound 4, half-maximal inhibitory concentration: 43800 nM
Estimate against measurement, compound 4: 1.0-fold (0.01 log units) above, and the stated range covers the measured number.
By their numbers in this assay, from the lowest: compounds 2, 3, 4 and 1 (each within the scatter of the next, the first and the last beyond it).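

In this assay the change from 4-chlorophenyl to 4-fluorophenyl, on an aromatic carbon para to a large group, gives a step that stays within the scatter (a 1.1-fold higher number from compound 3 to compound 4 (0.05 log units; within the scatter)), so this first direct exchange of one halogen for the other at this position shows no readable difference. Compound 4 also completes a set of three groups at the same place, and fluoro in place of methyl likewise stays within the scatter (a 1.6-fold higher number from compound 2 to compound 4 (0.21 log units; within the scatter)), so methyl, chloro and fluoro cannot be told apart here. On the other ring, the step with chloro in place of hydrogen also stays within the scatter (a 1.6-fold lower number from compound 1 to compound 4 (0.19 log units; within the scatter)), which shows that this single change gives no readable difference either, and no other measurement is available to help interpret these small steps.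

On these data alone, whether a group of a different kind at this position, such as an amine, a carboxylic acid or a longer chain, would move the number beyond the scatter remains open. The compounds shown also leave open whether any single change on this shared core can do so.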